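Phenyl for phenoxy on the tropone core: oxamate series

A few compounds are considered here, and "the series" means these few. Any claim that something is new, unique, unknown or untested is made for them only; others in the source may bear on it.

Measured so far:
compound 1, `CCOC(=O)C(=O)Nc1ccc(O)c(=O)cc1` — 10%
compound 2, `CCOC(=O)C(=O)Nc1ccccc(Oc2ccccc2)c1=O` — 16%

In a functional assay on the whole organism (strain Sprague-Dawley CD) for inhibition, with Rattus norvegicus as the target, read by paw edema, at a dose of 30 mg/kg by the intraperitoneal route (a lower number here means a weaker effect, a higher number a stronger effect of the compound at the dose given), compound 1 gives 10% and compound 2 gives 16%. Compound 2 carries the larger of the two figures, yet the gap to compound 1 lies within the scatter of repeated measurements, so the two values cannot be told apart. Among the compounds with values here, no step between measured compounds that differ in one place is available; the two compounds differ in more than one place at once.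

Compound 3, `CCOC(=O)C(=O)Nc1ccccc(-c2ccccc2)c1=O`, is not yet measured in this assay. It differs from compound 2 as follows: phenyl in place of phenoxy on an aromatic carbon. Both measured values sit at the low end of the read-out, and nothing in the pair of numbers points to a larger effect from this exchange. The expected step is a number 1 percentage points lower from compound 2 to compound 3 (within the scatter), no change beyond the scatter. Compound 3 is therefore expected to give about 15%, with a range from 4% to 30%.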

Compound 3, a percentage reported as inhibition, in the whole organism at one dose (the size of the read-out at that dose, not a potency): 72%
For compound 3 the middle estimate is 57 percentage points below the measured one; the whole stated range lies below it.
By their numbers in this assay, from the lowest: compounds 1 and 2 (each within the scatter of the next); then compound 3.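

In this assay, the group on this aromatic carbon of the seven-membered ring, two ring bonds from the ring atom that bears a group of 8 heavy atoms, proves able to move the read-out far beyond the scatter: phenyl in place of phenoxy gives a number 56 percentage points higher from compound 2 to compound 3 (beyond the scatter) at the one dose used. The two groups share the same six-membered aromatic ring of carbon only and differ by the oxygen and its hydrogen-bond acceptor, so a change this small in what is counted is enough for a large step in the whole organism. Nothing measured here bears on the reason for this step.

On these data alone, whether the higher figure needs an aromatic ring joined directly at this place remains open, and a cyclohexyl ring, a benzyl group or a methyl group in the same place would separate these readings. Also open, as far as these compounds go, is how the read-out of the phenyl compound responds at the other end of the molecule, for instance with a carboxylic acid in place of the ethyl ester.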